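Adding ethyl to an inactive chloro compound

The source may report more compounds than this note shows. Statements on the series, on what has been measured and on what is new or still open speak of the compounds shown alone.

Compound 1 (`CCCCCCCC(CCO)n1cnc2c(N)ncnc21`) gives > 50000 nM in a functional assay on HCT-116 cells (Homo sapiens) for antiproliferative activity, read by MTT assay, with a stated time of 48 h (on this read-out lower numbers stand for stronger inhibition and higher numbers for weaker inhibition), as a limit and not a number. Compound 2 (`CCCCCCCC(CCO)n1cnc2c(N)nc(Cl)nc21`) gives > 50000 nM in this assay and this too is only a limit. The chloro change is a step that the two limits leave unreadable from compound 1 to compound 2 and so offers no size to carry forward. Compound 3 (`CCCCCCCCCC(CCO)n1cnc2c(N)nc(Cl)nc21`) brings ethyl in place of hydrogen on a saturated chain carbon, eight bonds along the chain from an aromatic nitrogen on the chain of compound 2. Going by the values given here, the only evidence is the limit of > 50000 nM in this assay, at which 2 of the 2 values shown sit, so little gain is expected and the estimated size is an at least 1.4-fold lower number from compound 2 to compound 3 (0.15 log units; that floor lies within the scatter) towards stronger inhibition. For compound 3 the estimate is 35000 nM with an expected range from 12000 nM to 80000 nM and the assay may well report a limit again.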

Compound 3, half-maximal inhibitory concentration: 14800 nM
Compound 3: middle estimate off by 2.4-fold (0.37 log units), on the high side, and the stated range covers the measured number.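

Lengthening the chain at this position moves the series off the assay limit, with an at least 3.3-fold lower number from compound 2 to compound 3 (0.52 log units; beyond the scatter) in this assay. Going by these compounds alone, the chloro step from compound 1 to compound 2 cannot be read, so this is the first sign that a change here can be measured. The true size may be larger, as this step has only a floor: the limit of > 50000 nM in this assay, at which 2 of the 3 values shown sit.

From the compounds shown here alone, whether a longer chain would lower the number further, or an amine or a carboxylic acid at this position would keep the activity, stays open. So does whether the ethyl gain depends on the chloro.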